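Swapping the aryl group on a ring nitrogen

A few compounds are considered here, and "the series" means these few. Any claim that something is new, unique, unknown or untested is made for them only; others in the source may bear on it.

Compound 1 `O=C1N/C(=C\c2ccc(Cl)cc2)C(=O)N1c1ccc(Cl)cc1`: 35600 nM
Compound 2 `Cc1ccc(N2C(=O)N/C(=C\c3ccc(O)cc3)C2=O)cc1`: 27900 nM
Compound 3 `COc1ccc(N2C(=O)N/C(=C\c3ccc(O)cc3)C2=O)cc1`: a limit, > 200000 nM

In a functional assay on NCI-H292 cells (Homo sapiens) for antiproliferative activity (on this read-out lower numbers stand for stronger inhibition and higher numbers for weaker inhibition), compound 2 gives 27900 nM, and compound 1 gives 35600 nM, the two numbers sitting within the scatter of each other. Compound 3 reaches only a limit (the limit of > 200000 nM in this assay, at which 1 of the 3 values shown sits). Compound 4 `O=C1N/C(=C\c2ccc(O)cc2)C(=O)N1c1cccc(I)c1` differs from compound 2 by 3-iodophenyl in place of 4-methylphenyl on an amide-type nitrogen in a ring. Going by the values given here, the one measured step on this ring, an at least 7.1-fold higher number from compound 2 to compound 3 (0.85 log units; beyond the scatter), exchanges a different group, so no measured step covers an iodine on this ring. With nothing to anchor the change, compound 4 is expected to stay near compound 2, and the estimate is 30000 nM (range 10000 nM to 100000 nM), an expected step of a 1.1-fold higher number from compound 2 to compound 4 (0.03 log units; within the scatter) that need not exceed the scatter.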

Compound 4, half-maximal inhibitory concentration: > 200000 nM
Compound 4: no number, only a limit; the forecaster's own chance of this, stated with the estimate: 20%; at least 6.6-fold (0.82 log units) between middle value and limit.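

In this assay, 3-iodophenyl in place of 4-methylphenyl on an amide-type nitrogen in a ring gives an at least 7.1-fold higher number from compound 2 to compound 4 (0.85 log units; beyond the scatter). A second replacement at this position therefore also loses the activity of compound 2, so the earlier methoxy step is not a lone case. Compound 4 reaches only a limit, as compound 3 does, and the two cannot be ranked against each other: the limit of > 200000 nM in this assay, at which 2 of the 4 values shown sit.

Compound 4 changes both the substituent and its place on the phenyl ring, and the compounds shown do not separate these two changes. On these data alone, how an amine or a carboxylic acid on this phenyl ring would behave stays open.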